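Epoxide esters in the rat glucose tolerance test

The compounds below may be only part of what the source reports. "The series", "measured", "known", "first", "only" and "open" are said of these compounds alone.

Of the compounds shown here, three have been measured in a functional assay on the whole organism with Rattus norvegicus as the target, in the glucose tolerance test; on this read-out higher numbers stand for an effect only at larger amounts of compound and lower numbers for an effect already at smaller amounts. Compound 1 `CCCCC/C=C/CCCCCCCCCC1(C(=O)OC)CO1` gives 10 mg/kg in this assay, which places it second highest of the three numbers: its nearest neighbour is compound 3 `CCCCCCCCCCCCCCC1(C(=O)OCCCC)CO1`, which gives 1.5 mg/kg, and its furthest is compound 2 `CCCCCCCCCCCCCCC1(C(=O)NCCO)CO1`, which gives 100 mg/kg. Among the compounds with values here, the only step between compounds that differ in one place is a 67-fold lower number from compound 2 to compound 3 (1.82 log units; beyond the scatter), butoxy in place of (2-hydroxyethyl)amino on a carbonyl carbon.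

Compound 4 `CCCCCCCCCCCCC1(C(=O)OC)CO1` has not yet been measured. It differs from compound 1 in the chain, not at the carbonyl carbon: propyl in place of hept-1-en-1-yl on a saturated chain carbon, nine bonds along the chain from a saturated ring carbon. Within the data shown here, no measured step touches the chain; compound 1 and compound 3 differ both in the chain and at the carbonyl carbon, so their gap cannot be assigned to either change alone. The step of a 67-fold lower number from compound 2 to compound 3 (1.82 log units; beyond the scatter) concerns the carbonyl substituent and does not bear on this change. Among the measured compounds shown here, with no precedent for the chain, the expected step of no change at the digits printed from compound 1 to compound 4 (within the scatter) is none beyond the scatter, with wide uncertainty either way. Compound 4 is therefore estimated at 10 mg/kg in this assay, within a range of 3 mg/kg to 30 mg/kg.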

Compound 4, minimum effective dose: 5 mg/kg
Compound 4: the middle estimate sits 2.0-fold (0.30 log units) above what was measured; the range from low to high includes it.
By their numbers in this assay, from the lowest: compound 3; then compounds 4 and 1 (each within the scatter of the next); then compound 2.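

In this assay the chain now has a step of its own: a 2.0-fold lower number from compound 1 to compound 4 (0.30 log units; within the scatter), so propyl in place of hept-1-en-1-yl, on a saturated chain carbon nine bonds along the chain from a saturated ring carbon, does not move the number beyond the scatter. The earlier compounds shown here offered only a step at the carbonyl carbon, and this result shows that the far end of the chain can change in both length and saturation with compound 1 and compound 4 remaining within the scatter of each other. The two changes arrive together, and no data shown here separate them or explain the result.

A heptyl group at this place would separate the loss of the double bond from the shortening of the chain, while a longer saturated chain would test whether the flat result holds beyond the range covered by compound 1 and compound 4. Within the data shown here, also open is how a carboxylic acid in place of the methyl ester would behave on the chain of compound 4, as the only measured step at the carbonyl carbon joins an amide to a butyl ester.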